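This account rests on a few compounds, and the source may have more. Where it says the series, first, only, none or still open, it means among the compounds named here.

Compound 2 `CC1=C(C(=O)OC(C)C)C(c2cccs2)NC(=O)N1C` gives 28% in an assay on HEK293 cells for displacement of a labelled ligand from adenosine receptor A2b (Homo sapiens), with a stated time of 30 min, tested at 10 uM (on this read-out lower numbers stand for less inhibition and higher numbers for more inhibition at the one concentration tested (going by the name of the read-out)), and stands highest of the two numbers recorded; compound 1 `CCOC(=O)C1=C(C)N(C)C(=O)NC1c1cccs1` gives 11% in this assay. Going by the values given here, the only measured step, a number 17 percentage points higher from compound 1 to compound 2 (beyond the scatter), puts methyl in place of hydrogen on a saturated chain carbon and leaves the thiophen-2-yl untouched. Compound 3 `CC1=C(C(=O)OC(C)C)C(c2ccoc2)NC(=O)N1C` differs from compound 2 by furan-3-yl in place of thiophen-2-yl on a saturated ring carbon. Among the compounds with values here, no measured step bears on this exchange, so in this assay no change beyond the scatter is expected. The step of a number 6 percentage points lower from compound 2 to compound 3 (within the scatter) is expected to stay small. Compound 3 is therefore estimated at 22%, with a range from 5% to 40%.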

Compound 3, a percentage reported as inhibition, at one concentration (the size of the read-out at that concentration, not a potency): 35%
Estimate against measurement, compound 3: 13 percentage points below; low and high end bracket the measured number.
By their numbers in this assay, from the lowest: compound 1; then compounds 2 and 3 (each within the scatter of the next).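

Furan-3-yl can stand in place of thiophen-2-yl on the saturated ring carbon next to the ring nitrogen without a change beyond the scatter in this assay (a number 7 percentage points higher from compound 2 to compound 3 (within the scatter)). With the isopropoxycarbonyl group held constant, exchanging sulfur for oxygen and moving the ring attachment point together leaves the read-out level, so the two effects cannot be separated here. No supporting data bear on this exchange.

Open, on these data alone, is whether a phenyl or furan-2-yl group at this carbon stays at this level. Also open, as far as these compounds go, is whether the ethyl ester paired with furan-3-yl repeats the step seen with thiophen-2-yl.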